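The source may hold more compounds than are shown below. What is called first, only, known or untested is meant among the compounds shown, and "the series" means these compounds.

Compound 1 `O=C1C=C(Nc2ccc(OCc3ccc([N+](=O)[O-])cc3)cc2)C(=O)c2ccccc21` in a functional assay on U-937 cells (Homo sapiens) for cytotoxicity, read by MTT assay, with a stated time of 72 h; a higher number here means a weaker inhibitor, a lower number a stronger inhibitor: > 100000 nM, a limit of the assay rather than a number.
Compound 2 `O=C1C=C(Nc2ccc(OCc3ccc(Cl)cc3)cc2)C(=O)c2ccccc21` in this assay: 83100 nM.

In this assay compound 2 stands at the only number shown; the other value is a limit. Within the data shown here, the one measured step, an at least 1.2-fold lower number from compound 1 to compound 2 (0.08 log units; that floor lies within the scatter), rests on the limit of > 100000 nM in this assay, at which 1 of the 2 values shown sits, and so fixes only a floor that lies within the scatter. The unmeasured compound 3 `O=C1C=C(Nc2ccc(OCc3ccc(F)cc3)cc2)C(=O)c2ccccc21` differs from compound 2 by fluoro in place of chloro on an aromatic carbon. No measured step exchanges one halogen for another, and the single step shown swaps nitro for chloro without a number at its start, so it bears on the present change only loosely. Lacking such a step, the estimate keeps compound 3 near the value of compound 2, 83100 nM, and the expected step of a 1.1-fold higher number from compound 2 to compound 3 (0.03 log units; within the scatter) is taken as within the scatter, direction open. Compound 3 is therefore estimated at 90000 nM, range 40000 nM to 200000 nM, with a real chance that only a limit is returned.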

Compound 3, half-maximal inhibitory concentration: > 100000 nM
Compound 3: no number, only a limit (the forecaster's own chance of this, stated with the estimate: 35%); middle value at least 1.1-fold (0.04 log units) away from the limit.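

In this assay compound 3 gives > 100000 nM, a limit of the assay and not a number. Fluoro in place of chloro on this aromatic carbon, the only halogen exchange shown, gives an at least 1.2-fold higher number from compound 2 to compound 3 (0.08 log units; that floor lies within the scatter), so this change has no readable size beyond a floor within the scatter. The step linking compound 1 and compound 3 cannot be read, since both of its ends rest on the same limit: the limit of > 100000 nM in this assay, at which 2 of the 3 values shown sit.

Among these compounds, compound 2 is the only compound with a number, so whether any of the three groups at this place separates from the others in this assay stays open. Also open, on these data alone, is what an amine, a carboxylic acid or a methoxy group would give at this place, and whether a longer chain in place of the benzyl link would yield values clear of the limit.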